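Adding a Methoxy Group on the Anilino Ring

The compounds below may be only part of what the source reports. "The series", "measured", "known", "first", "only" and "open" are said of these compounds alone.

Of the compounds shown here, two have been tested in a functional assay on HCT-116 cells (Homo sapiens) for antiproliferative activity, read by MTT assay; a higher number here means a weaker inhibitor, a lower number a stronger inhibitor. Compound 1 `COc1ccc(CNc2ccc(/C=C/C(=O)Nc3ccccc3N)cc2)cc1` gives 37000 nM in this assay, while compound 2 `Nc1ccccc1NC(=O)/C=C/c1ccc(CNc2ccccc2)cc1` gives 11000 nM, the lower of the two numbers. Compound 3 `COc1cccc(NCc2ccc(/C=C/C(=O)Nc3ccccc3N)cc2)c1` is not yet measured; it differs from compound 2 by methoxy in place of hydrogen on an aromatic carbon, placed meta to a large group on the anilino ring. Among the measured compounds shown here, no measured step of this kind exists, so the expected step of a 1.4-fold higher number from compound 2 to compound 3 (0.13 log units; within the scatter) is small, at most a modest rise and possibly none beyond the scatter. Compound 3 is estimated at 15000 nM in this assay, within a range of 5000 nM to 45000 nM.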

Compound 3, half-maximal inhibitory concentration: 10000 nM
The estimate for compound 3 lay 1.5-fold (0.18 log units) above the measured number; the range from low to high includes it.
By their numbers in this assay, from the lowest: compounds 3 and 2 (each within the scatter of the next); then compound 1.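

In this assay, methoxy in place of hydrogen on an aromatic carbon, meta to a large group, gives a 1.1-fold lower number from compound 2 to compound 3 (0.04 log units; within the scatter) and so this position carries the group with no change that stands out from the scatter. Among the compounds shown here, this is the first step between compounds that differ in one place, which the earlier pair of compounds could not provide. No measurement offered here accounts for this result. The compounds shown leave open whether an amine or a carboxylic acid in place of the methoxy would leave the number equally unmoved, and whether methoxy elsewhere on this ring would do the same.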